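The compounds below may be only part of what the source reports. "The series", "measured", "known", "first", "only" and "open" are said of these compounds alone.

Working notes on the series, read in a functional assay on HL-60 cells (Homo sapiens) for antiproliferative activity, read by MTT assay, with a stated time of 72 h; on this read-out higher numbers stand for weaker inhibition and lower numbers for stronger inhibition. For the measured compounds named here, compound 2 (`COc1ccc(-c2ncnn2-c2cc(OC)c(OC)c(OC)c2)cc1`) gives 120 nM, the only actual number so far. Compound 1 (`COc1cc(-c2ncnn2-c2cccc(F)c2)cc(OC)c1OC`) gives > 10000 nM, which is a limit. Compound 3 (`COc1cc(-c2ncnn2-c2ccc(N)cc2)cc(OC)c1OC`) gives > 10000 nM, which is also a limit. Going by the values given here, the one measured step is a step that the two limits leave unreadable from compound 1 to compound 3, so it offers no size to carry forward.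

Compound 4 (`COc1cc(-n2ncnc2-c2ccc(Cl)c(Cl)c2)cc(OC)c1OC`) departs from compound 2 by one change: 3,4-dichlorophenyl in place of 4-methoxyphenyl on an aromatic carbon. In words, 3,4-dichlorophenyl replaces 4-methoxyphenyl on an aromatic carbon of a five-membered aromatic ring with 3 nitrogen. Among the compounds with values here, no measured step covers this change, so the data give direction only weakly and size hardly at all.

A step toward weaker inhibition in this assay is still expected because of the limit of > 10000 nM in this assay, at which 2 of the 3 values shown sit, with compound 1 and compound 3 both resting there. The range is kept wide, and a result at the limit for compound 4 would not be a surprise. The expected step is a 13-fold higher number from compound 2 to compound 4 (1.10 log units; beyond the scatter). For compound 4 the estimated value is 1500 nM, with an expected range from 250 nM to 8000 nM.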

Compound 4, half-maximal inhibitory concentration: > 10000 nM
Compound 4 ended at the assay's limit; the forecaster's own chance of this, stated with the estimate: 25%; at least 6.6-fold (0.82 log units) between middle value and limit.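

In this assay, the aromatic carbon of the five-membered aromatic ring with 3 nitrogen now has its first readable step, and it is large: an at least 83-fold higher number from compound 2 to compound 4 (1.92 log units; beyond the scatter) with 3,4-dichlorophenyl in place of 4-methoxyphenyl. The change leaves the heavy-atom count of the group and its six-membered aromatic ring of carbon only as they were, and it takes away the one hydrogen-bond acceptor of the group, but this single pair cannot separate the loss of the methoxy group from the arrival of the two chlorine atoms. For compound 4 the value of > 10000 nM is a limit, and the series gathers there: the limit of > 10000 nM in this assay, at which 3 of the 4 values shown sit.

On these data alone, whether a single chlorine on the phenyl ring would give a readable number at this carbon stays open, as does the result of a hydroxyl, an amine or an ethoxy group in place of the methoxy group of 4-methoxyphenyl. The full size of the step also stays open, and the compounds shown give only this one pair for judging the group on this carbon.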